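Chloro for Methyl on the Piperazine Benzyl Arm

The source may report more compounds than this note shows. Statements on the series, on what has been measured and on what is new or still open speak of the compounds shown alone.

Three compounds share one core and differ only in the group on an amine nitrogen in a ring. Compound 1 `CN(C)/C=C/N1CCN(CC(=O)Nc2ccc(-c3nc(-c4ccccc4)c(-c4ccccc4)n3C)cc2)CC1` carries a 2-(dimethylamino)ethenyl group there; in a functional assay on HT-29 cells (Homo sapiens) for cytotoxicity, read by MTT assay, with a stated time of 24 h, tested at 6.4 ug/mL (on this read-out higher numbers stand for a stronger effect at the one concentration tested and lower numbers for a weaker effect), compound 1 gives 12.2%. Compound 2 `Cn1c(-c2ccc(NC(=O)CN3CCN(c4ccccc4)CC3)cc2)nc(-c2ccccc2)c1-c1ccccc1` carries a phenyl and gives 46.5%. Compound 3 `Cc1ccc(CN2CCN(CC(=O)Nc3ccc(-c4nc(-c5ccccc5)c(-c5ccccc5)n4C)cc3)CC2)cc1` carries a 4-methylbenzyl and gives 27.7%, the second highest of the three numbers. The measured steps are a number 34.3 percentage points higher from compound 1 to compound 2 (beyond the scatter), a number 15.5 percentage points higher from compound 1 to compound 3 (beyond the scatter) and a number 18.8 percentage points lower from compound 2 to compound 3 (beyond the scatter).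

Compound 4 `Cn1c(-c2ccc(NC(=O)CN3CCN(Cc4ccc(Cl)cc4)CC3)cc2)nc(-c2ccccc2)c1-c1ccccc1` differs from compound 3 in one place: chloro in place of methyl on an aromatic carbon. Among the compounds with values here, no measured step touches a substituent on that aromatic ring; the three steps each exchange the whole group on the ring nitrogen, so they say little about this smaller change. A step within the scatter is therefore expected, with no clear direction.

Compound 4 is expected to give about 30%, within 15% to 45%, which means an expected step of a number 2.3 percentage points higher from compound 3 to compound 4 (within the scatter).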

Compound 4, a percentage reported as activity, at one concentration (the size of the read-out at that concentration, not a potency): 41.5%
For compound 4 the middle estimate is 11.5 percentage points below the measured one; the range from low to high includes it.
By their numbers in this assay, from the lowest: compound 1; then compound 3; then compounds 4 and 2 (each within the scatter of the next).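

In this assay the exchange of methyl for chloro gives a number 13.8 percentage points higher from compound 3 to compound 4 (beyond the scatter) and so counts for more than its size suggests, since one heavy atom replaces one heavy atom on the aromatic ring of the benzyl arm. This small change also alters how the benzyl arm compares with the other groups on the ring nitrogen: the 4-methylbenzyl arm gave a number 18.8 percentage points lower from compound 2 to compound 3 (beyond the scatter) whereas the 4-chlorobenzyl arm gives a number 5 percentage points lower from compound 2 to compound 4 (within the scatter) and, against the 2-(dimethylamino)ethenyl group, a number 29.3 percentage points higher from compound 1 to compound 4 (beyond the scatter) in the same assay. Nothing measured here explains the effect of the chloro group.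

As far as these compounds go, whether this step is particular to chloro remains open, as fluoro, bromo, methoxy or trifluoromethyl in the same place could follow it or depart from it. These numbers also come from one concentration, so they do not give a potency for any of the compounds.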